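The source may hold more compounds than are shown below. What is called first, only, known or untested is meant among the compounds shown, and "the series" means these compounds.

Compound 1 `CCc1onc(NS(=O)(=O)c2ccc(C(C)(C)C)cc2)c1Sc1cccc(OC)c1` gives 2800 nM in an assay on COS-7 cells for displacement of a labelled ligand from Endothelin receptor type B (Sus scrofa); a higher number here means a weaker inhibitor, a lower number a stronger inhibitor.
Compound 2 `COc1cccc(Sc2c(NS(=O)(=O)c3ccc(C(C)(C)C)cc3)noc2CO)c1` gives 560 nM in this assay.
Compound 3 `COc1cccc(Sc2c(NS(=O)(=O)c3ccc(C(C)(C)C)cc3)noc2CCC=O)c1` gives 500 nM in this assay.

Compound 3 holds the lowest number of the three, yet the step of a 1.1-fold lower number from compound 2 to compound 3 (0.05 log units; within the scatter) lies within the scatter, so compound 2 and compound 3 cannot be told apart; only compound 1 stands clearly apart a 5.6-fold lower number from compound 1 to compound 3 (0.75 log units; beyond the scatter). Compound 4 `COc1cccc(Sc2c(NS(=O)(=O)c3ccc(C(C)(C)C)cc3)noc2CCCC(N)=O)c1` keeps the shared core and changes the chain: carbamoylmethyl in place of formyl on a saturated chain carbon, two bonds along the chain from an aromatic carbon. Going by the values given here, the one step that bears on this, a 1.1-fold lower number from compound 2 to compound 3 (0.05 log units; within the scatter), swapped one chain end for another and changed nothing beyond the scatter, so a further swap of the same kind is expected to move the number little in this assay, with no clear direction. The expected step is a 1.1-fold lower number from compound 3 to compound 4 (0.05 log units; within the scatter). Compound 4 is therefore estimated at 450 nM, within 150 nM to 1500 nM.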

Compound 4, half-maximal inhibitory concentration: 240 nM
The estimate for compound 4 lay 1.9-fold (0.27 log units) above the measured number, within the range that was stated.
By their numbers in this assay, from the lowest: compound 4; then compounds 3 and 2 (each within the scatter of the next); then compound 1.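

In this assay the chain end now matters: a 2.1-fold lower number from compound 3 to compound 4 (0.32 log units; beyond the scatter) lies beyond the scatter, which the earlier swap of chain ends did not. Going by these compounds alone, the 3-carbamoylpropyl chain also beats the hydroxy end in a 2.3-fold lower number from compound 2 to compound 4 (0.37 log units; beyond the scatter) and gives the first large step at this position in a 12-fold lower number from compound 1 to compound 4 (1.07 log units; beyond the scatter) against the plain ethyl chain. No measurement shown accounts for this gain.

Compound 4 changes the chain end and its length together, and these two cannot be separated here. A shorter 2-carbamoylethyl chain, or a carboxylic acid or an amine at the chain end, would test which one counts.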